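Carboxy-fluorophenyl for propoxycarbonylphenyl on the amide nitrogen

The source may hold more compounds than are shown below. What is called first, only, known or untested is meant among the compounds shown, and "the series" means these compounds.

Compound 1 `COCCOC(=O)c1ccc(F)c(C(=O)Nc2cccc(-c3cc(C(=O)Nc4ccncc4F)ccc3CN)c2)c1` and compound 2 `CCCOC(=O)c1ccc(NC(=O)c2cccc(-c3cc(C(=O)Nc4ccncc4F)ccc3CN)c2)cc1` share a core and differ only in the aryl group carried on one amide nitrogen. In an assay on cells for inhibition of Rho-associated protein kinase 2 (Homo sapiens), read by radiometric assay and 33P incorporation, in the presence of a further agent that is not named here (on this read-out lower numbers stand for stronger inhibition and higher numbers for weaker inhibition), compound 1 gives < 1 nM, which is a limit of the assay and not a number. In this assay compound 2 gives < 1 nM, again a limit of the assay. Compound 2 therefore stands at the limit of < 1 nM in this assay, at which 2 of the 2 values shown sit. Within the data shown here, with both values at the limit, the two compounds cannot be ordered against each other, and no measured step between them is available.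

Compound 3 `NCc1ccc(C(=O)Nc2ccncc2F)cc1-c1cccc(C(=O)Nc2cccc(C(=O)O)c2F)c1` is not yet measured. It differs from compound 2 by 3-carboxy-2-fluorophenyl in place of 4-(propoxycarbonyl)phenyl on an amide-type nitrogen. Since both measured compounds sit at the limit, the series gives no direction for this change. The step in this assay is expected to be small, an at least 1.5-fold higher number from compound 2 to compound 3 (0.17 log units; that floor lies within the scatter), and possibly none beyond the scatter. Compound 3 is expected to give 1.5 nM in this assay, with a range from 0.3 nM to 8 nM, and with a real chance that the assay again reports only a limit.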

Compound 3, half-maximal inhibitory concentration: 3.5 nM
The estimate for compound 3 lay 2.3-fold (0.37 log units) below the measured number; measured number inside the range.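

In this assay, among these compounds, this position gives a readable direction for the first time: 3-carboxy-2-fluorophenyl in place of 4-(propoxycarbonyl)phenyl on the amide-type nitrogen gives an at least 3.5-fold higher number from compound 2 to compound 3 (0.54 log units; beyond the scatter). So the aryl group on this nitrogen does affect the read-out, and this change weakens inhibition rather than leaving it unchanged within the scatter. Among the compounds shown here, compound 2 gives < 1 nM, which is a limit of the assay and not a number, so the step has only a floor and its full size remains unknown, while compound 3 provides the only value in the set that is not at that limit: the limit of < 1 nM in this assay, at which 2 of the 3 values shown sit.

The change replaces the whole aryl group, so the compounds shown do not separate the contribution of the carboxylic acid from that of the fluorine or of the substitution pattern on the ring. A carboxyphenyl group without fluorine, a fluorophenyl group without the carboxylic acid, or the propyl ester of the 3-carboxy-2-fluorophenyl group on the same nitrogen would assign the step to one of these parts.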